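The source may report more compounds than this note shows. Statements on the series, on what has been measured and on what is new or still open speak of the compounds shown alone.

Compound 2 `COc1cccc(/C=C2\CCC/C(=C\c3cccc(Br)c3)C2=O)c1OC` was tested in an ADME assay on NHDF cells (Homo sapiens) for cytotoxicity, read by MTT assay, with a stated time of 72 h (a lower number here means a stronger inhibitor, a higher number a weaker inhibitor), where compound 2 gives 23900 nM. Within the data shown here, its only measured neighbour is compound 1 `COc1cccc(/C=C2\CCC/C(=C\c3ccccc3Cl)C2=O)c1OC`, which in this assay gives 44200 nM. Among the measured compounds shown here, the one step joining them is a 1.8-fold lower number from compound 1 to compound 2 (0.27 log units; within the scatter), so the two numbers sit within the usual scatter of each other and compound 2 cannot be set apart from compound 1 on these data.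

Compound 3 `COc1cccc(/C=C2\CCC/C(=C\c3cccc(OC)c3OC)C2=O)c1` differs from compound 2 in a single place: methoxy in place of bromo on an aromatic carbon. For the measured compounds named here, no measured step covers a swap of bromo for methoxy; the only step available, a 1.8-fold lower number from compound 1 to compound 2 (0.27 log units; within the scatter), shows that changing the substituted phenyl group barely moved the number. A change of similar scale is therefore expected, with no clear direction. Compound 3 is estimated at 30000 nM in this assay, with a likely range from 12000 nM to 75000 nM. The step expected from this estimate is a 1.3-fold higher number from compound 2 to compound 3 (0.10 log units; within the scatter).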

Compound 3, half-maximal inhibitory concentration: 16400 nM
Beside the measured number, compound 3's estimate is 1.8-fold (0.26 log units) above it, and the stated range covers the measured number.
By their numbers in this assay, from the lowest: compounds 3, 2 and 1 (each within the scatter of the next, the first and the last beyond it).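

In this assay, the swap on this aromatic carbon reads as a 1.5-fold lower number from compound 2 to compound 3 (0.16 log units; within the scatter), so 3-bromophenyl and 3-methoxyphenyl cannot be told apart here, even though the methoxy group is larger by one heavy atom and brings a hydrogen-bond acceptor. Among these compounds, the other new comparison, a 2.7-fold lower number from compound 1 to compound 3 (0.43 log units; beyond the scatter), is the first step in this set to clear the scatter, though only modestly, and it shows that the substituted phenyl group can shift this number measurably. Nothing available explains either step.

The compounds shown leave open whether a group of a different kind at this position, such as an amine or a carboxylic acid, would move the number further. They also leave open whether the step away from 2-chlorophenyl depends on the chloro group itself or on where it sits on the ring.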